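A few compounds are considered here, and "the series" means these few. Any claim that something is new, unique, unknown or untested is made for them only; others in the source may bear on it.

Measured in a functional assay on K562 cells (Homo sapiens) for antiproliferative activity, read by MTT assay, with a stated time of 48 h; on this read-out higher numbers stand for weaker inhibition and lower numbers for stronger inhibition:
Compound 1 `Cn1cc(C2=C(c3nn(CCCn4cncn4)c4ncccc34)C(=O)NC2=O)c2ccccc21`: > 100000 nM (a limit)
Compound 2 `Cn1cc(C2=C(c3nn(CCCn4cncn4)c4ncccc34)C(=O)N(c3ccccc3)C2=O)c2ccccc21`: > 100000 nM (a limit)
Compound 3 `Cn1cc(C2=C(c3nn(CCCN4CCCCC4)c4ncccc34)C(=O)N(c3ccc(Cl)cc3)C2=O)c2ccccc21`: 1800 nM

Compound 1 has no numerical potency on this read-out, since its > 100000 nM is a limit and not a number. The same holds for compound 2, and the limit of > 100000 nM in this assay, at which 2 of the 3 values shown sit, is where the two share their position.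

The change under review leads to compound 4 `Cn1cc(C2=C(c3nn(CCCn4ccnc4)c4ncccc34)C(=O)NC2=O)c2ccccc21`: 1H-imidazol-1-yl in place of 1H-1,2,4-triazol-1-yl on a saturated chain carbon, three bonds along the chain from an aromatic nitrogen.

Within the data shown here, no measured step covers this exchange. Among the measured compounds shown here, the only step available is a step that the two limits leave unreadable from compound 1 to compound 2, which has no readable size and concerns another place in the molecule. Compound 3 alone gives a number, 1800 nM, but it differs from compound 1 in more than one place and cannot size this exchange.

The expectation in this assay therefore rests mainly on the limit of compound 1, and a clear gain is not expected. Compound 4 may well also return only a limit. Any readable number is expected to lie near the top of the measurable range, on the side of slightly stronger inhibition. The estimated change is an at least 1.2-fold lower number from compound 1 to compound 4 (0.09 log units; that floor lies within the scatter). For compound 4 the expected value is 80000 nM, with an estimated range of 15000 nM to 150000 nM.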

Compound 4, half-maximal inhibitory concentration: 13800 nM
Compound 4: the middle estimate sits 5.8-fold (0.76 log units) above what was measured; the measured number lies below the stated range.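

In this assay, 1H-imidazol-1-yl in place of 1H-1,2,4-triazol-1-yl, on a saturated chain carbon three bonds along the chain from an aromatic nitrogen, gives an at least 7.2-fold lower number from compound 1 to compound 4 (0.86 log units; beyond the scatter), so this position responds to an exchange of one five-membered aromatic ring for another. The step with phenyl on the amide-type nitrogen cannot be read, which leaves this exchange as the only change shown with a readable direction, and compound 4 shows that a readable number in this series does not need a substituent in place of the amide hydrogen. The step remains a floor and not a full size because the starting point, compound 1, stands at a limit of the assay: the limit of > 100000 nM in this assay, at which 2 of the 4 values shown sit.

Open, as far as these compounds go, is whether phenyl or 4-chlorophenyl on the amide-type nitrogen would add to or cancel this gain with 3-(1H-imidazol-1-yl)propyl in place, since compound 3 differs from compound 4 in more than one place and cannot be compared with it. Also open, from the compounds shown here alone, is how the same position would respond to a morpholine, a dimethylamino group or a longer chain carrying the imidazole.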